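Trifluoromethyl Ketone Thiophenes: Pyridyl Oxadiazole to Thienylmethyl

A few compounds are considered here, and "the series" means these few. Any claim that something is new, unique, unknown or untested is made for them only; others in the source may bear on it.

Measured so far:
compound 1, `O=C(c1ccc(-c2nc(-c3ccccn3)no2)s1)C(F)(F)F`: 90 nM
compound 2, `O=C(NCc1ccccc1)c1ccc(C(=O)C(F)(F)F)s1`: 243 nM

Both compounds were tested in an assay for inhibition of histone deacetylase 4 (Homo sapiens); on this read-out higher numbers stand for weaker inhibition and lower numbers for stronger inhibition. Compound 1 gives 90 nM, the lowest of the two numbers; compound 2, which carries a benzylamide in place of the oxadiazole, gives 243 nM, a higher number by a gap that lies beyond the usual scatter. Within the data shown here, no pair of the measured compounds differs in one place only, so no single structural step has yet been tied to a change in this assay.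

Compound 3, `O=C(c1ccc(-c2nc(Cc3cccs3)no2)s1)C(F)(F)F`, is the next compound and is not yet measured. It differs from compound 1 in one place: (thiophen-2-yl)methyl in place of pyridin-2-yl on an aromatic carbon. The rest of the shared core, with its trifluoromethyl ketone on the thiophene, is kept.

Among the measured compounds shown here, with no measured step of this kind to draw on, only a guarded expectation is possible. The step from compound 1 to compound 3 is expected to be a 2.2-fold higher number from compound 1 to compound 3 (0.35 log units; beyond the scatter), modest and toward weaker inhibition, though a change within the scatter cannot be ruled out. Compound 3 is therefore estimated at 200 nM, in a range from 60 nM to 700 nM.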

Compound 3, half-maximal inhibitory concentration: 15 nM
Beside the measured number, compound 3's estimate is 13-fold (1.12 log units) above it, and the stated range ends above it.
By their numbers in this assay, from the lowest: compound 3; then compound 1; then compound 2.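

The first single-place step measured in this assay is a 6.0-fold lower number from compound 1 to compound 3 (0.78 log units; beyond the scatter), which shows that the aromatic carbon between two ring nitrogen atoms is a place where a change of group moves the number beyond the scatter. Pyridin-2-yl is also not needed there for a low number: (thiophen-2-yl)methyl matches it in heavy atoms, hydrogen-bond donors and hydrogen-bond acceptors, yet brings a five-membered aromatic ring with sulfur in place of a six-membered aromatic ring with nitrogen, and the number falls. Nothing measured here accounts for this fall.

This single step changes the ring and its attachment together, so the compounds shown cannot say which of the two goes with the lower number; thiophen-2-yl set directly on the carbon, or pyridin-2-ylmethyl, would divide the two. Also open, on these data alone, is how this position responds to a longer chain, such as 2-(thiophen-2-yl)ethyl, or to an amine, and whether the same group would have a similar effect with the benzylamide of compound 2 in the molecule.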